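The compounds below may be only part of what the source reports. "The series", "measured", "known", "first", "only" and "open" are said of these compounds alone.

Measured so far:
compound 1, `CN1CCCN(CCn2ccc3cc(Br)ccc32)CC1`, 65%
compound 2, `CN1CCCN(CCn2ccc3ccc(Cl)cc32)CC1`, 85%

Of the compounds shown here, two sharing the same core have been tested in an assay on HEK293 cells for binding affinity to 5-hydroxytryptamine receptor 7 (Homo sapiens), read by radioligand binding, tested at 1 uM; a lower number here means less inhibition, a higher number more inhibition at the concentration tested (going by the name of the read-out). In this assay compound 1 gives 65%, and compound 2 gives 85%. Compound 2 therefore stands highest of the two numbers; the value of compound 1 lies lower by a gap that goes beyond the usual scatter of repeated measurements, so the two compounds can be told apart on this read-out.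

The next compound, compound 3, `CN1CCCN(CCn2ccc3ccc(C(C)(C)O)cc32)CC1`, has not yet been measured. It differs from compound 2 in one place: 1-hydroxy-1-methylethyl in place of chloro on an aromatic carbon. A small halogen is exchanged for a larger group carrying a hydroxyl, on the same aromatic carbon of the fused ring system.

Among the measured compounds shown here, no measured pair shows this kind of exchange, so the size of the step rests on expectation alone. The step from compound 2 to compound 3 is expected to be a number 30 percentage points lower from compound 2 to compound 3 (beyond the scatter), a fall beyond the scatter. Compound 3 is estimated to give 55% in this assay, with a range from 25% to 80%.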

Compound 3, a percentage reported as inhibition, at one concentration (the size of the read-out at that concentration, not a potency): 6%
The estimate for compound 3 lay 49 percentage points above the measured number, outside the stated range (below it).
By their numbers in this assay, from the lowest: compound 3; then compound 1; then compound 2.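

At this aromatic carbon, meta to a fused ring and para to a fused ring, putting 1-hydroxy-1-methylethyl in place of chloro gives, in this assay, a number 79 percentage points lower from compound 2 to compound 3 (beyond the scatter), a large step. This is the first exchange shown between two compounds differing in only one place, and it shows that the read-out can depend heavily on the group at this carbon: chloro cannot be swapped for just any group here without a major change in the number. The exchange alters the heavy atoms and adds a hydrogen-bond donor and acceptor all at once, and nothing available shows which of these changes matters or explains the fall.

On these data alone, what remains open is whether the fall goes with the hydroxyl or with the branched carbon frame, which a tert-butyl group, with the same frame and no oxygen, or a smaller hydroxymethyl group on the same carbon could help to separate. As far as these compounds go, it is also open how a methoxy group, an amine or a bromine at this carbon would fare, so the limits of what the position accepts remain undefined.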